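Amide variations on a shared piperidinyl-quinazoline core

This account rests on a few compounds, and the source may have more. Where it says the series, first, only, none or still open, it means among the compounds named here.

Three measured compounds share one core and differ only in the amide attached to the saturated ring. Compound 1 `CCNC(=O)C1CCN(c2nc(N)c3cc(OC)c(OC)cc3n2)CC1` gives 1.64 nM in an assay on isolated protein for displacement of a labelled ligand from Adrenergic receptor alpha-1 (Rattus norvegicus); a lower number here means a stronger inhibitor, a higher number a weaker inhibitor. Compound 2 `COCCNC(=O)C1CCN(c2nc(N)c3cc(OC)c(OC)cc3n2)CC1` gives 1.13 nM in this assay, and compound 3 `CCN(CC)C(=O)C1CCN(c2nc(N)c3cc(OC)c(OC)cc3n2)CC1` gives 1.11 nM. The step of a 1.5-fold lower number from compound 1 to compound 2 (0.16 log units; within the scatter) and the step of a 1.5-fold lower number from compound 1 to compound 3 (0.17 log units; within the scatter) both stay within the scatter, as does a 1.0-fold lower number from compound 2 to compound 3 (0.01 log units; within the scatter); compound 3 therefore stands level with compounds 1 and 2, and no ordering among the three can be claimed.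

Compound 4 `CCCNC(=O)CC1CCN(c2nc(N)c3cc(OC)c(OC)cc3n2)CC1` is the next member. The change from compound 3 is (propylcarbamoyl)methyl in place of diethylcarbamoyl on a saturated ring carbon, a rearrangement of the same atoms that moves the carbonyl one carbon away from the ring and brings back an amide hydrogen. Within the data shown here, the measured steps that bear on it are a 1.5-fold lower number from compound 1 to compound 3 (0.17 log units; within the scatter) and a 1.5-fold lower number from compound 1 to compound 2 (0.16 log units; within the scatter), both small and both concerning only the amide substituents; no measured step tests moving the carbonyl off the ring. On that basis a step of no more than the scatter is expected for compound 4 in this assay, in either direction, giving an expected step of a 1.4-fold higher number from compound 3 to compound 4 (0.16 log units; within the scatter). The value expected for compound 4 is 1.6 nM, within the range 0.5 nM to 5 nM.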

Compound 4, inhibition constant: 0.65 nM
Compound 4: the middle estimate sits 2.5-fold (0.39 log units) above what was measured, within the range that was stated.
By their numbers in this assay, from the lowest: compounds 4, 3, 2 and 1 (each within the scatter of the next, the first and the last beyond it).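

Moving the carbonyl one carbon away from the saturated ring carbon, with the amide hydrogen restored, leaves compound 4 level with two of its neighbours in this assay (a 1.7-fold lower number from compound 3 to compound 4 (0.23 log units; within the scatter); a 1.7-fold lower number from compound 2 to compound 4 (0.24 log units; within the scatter)), so this position accepts the longer attachment without any loss in binding. Among these compounds, only the comparison with the ethylcarbamoyl member reaches beyond the scatter, and modestly (a 2.5-fold lower number from compound 1 to compound 4 (0.40 log units; beyond the scatter)), making it the sole step among the four compounds that can be read as a real difference, though it joins the shift of the carbonyl with a longer chain on the amide nitrogen and cannot assign the difference to either. No supporting data bear on why compound 4 sits where it does.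

Whether the carbonyl shift or the propyl chain accounts for the step from compound 1 remains open, and (ethylcarbamoyl)methyl or (diethylcarbamoyl)methyl at the same ring carbon would separate the two. Going by these compounds, how this assay responds to a longer chain between ring carbon and carbonyl, or to a carboxylic acid or an amine in place of the amide, also remains open.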